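Swapping Hydroxy for Amino on the Carbonyl Carbon

A few compounds are considered here, and "the series" means these few. Any claim that something is new, unique, unknown or untested is made for them only; others in the source may bear on it.

The measured compounds, all tested in a functional assay for inhibition of nuclear factor NF-kappa-B complex (Homo sapiens); a higher number here means a weaker inhibitor, a lower number a stronger inhibitor:
Compound 1, `CCCC(=O)C1=Cc2ccc(OC)cc2OC1c1cc(OC)c(OC)c(OC)c1`, gives 11700 nM.
Compound 2, `CCCCNC(=O)C1=Cc2ccc(OC)cc2OC1c1cc(OC)c(OC)c(OC)c1`, gives 25500 nM.
Compound 3, `COc1ccc2c(c1)OC(c1cc(OC)c(OC)c(OC)c1)C(C(=O)O)=C2`, gives > 50000 nM.

Compound 3 stands at the floor of what this assay can report: its result is a limit, (the limit of > 50000 nM in this assay, at which 1 of the 3 values shown sits), not a number. The step to compound 4, `COc1ccc2c(c1)OC(c1cc(OC)c(OC)c(OC)c1)C(C(N)=O)=C2`, is amino in place of hydroxy on a carbonyl carbon.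

Two measured steps end at compound 3 and therefore bear on this change. Replacing propyl with hydroxy gave an at least 4.2-fold higher number from compound 1 to compound 3 (0.63 log units; beyond the scatter), and replacing butylamino with hydroxy gave an at least 1.9-fold higher number from compound 2 to compound 3 (0.29 log units; that floor lies within the scatter). Both point the same way: the hydroxy compound is the weakest of the three, and the amide compound 2 sits nearer the ketone compound 1 than the acid does. Going back from hydroxy to an amine, here a bare amino rather than butylamino, is therefore expected to lower the number again, most likely to a value in the region of compound 2 or somewhat above it, though the limit for compound 3 leaves the size of that step uncertain.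

Compound 4 is thus estimated at 30000 nM, with a range from 12000 nM to 80000 nM, which means an expected step of an at least 1.6-fold lower number from compound 3 to compound 4 (0.22 log units; that floor lies within the scatter).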

Compound 4, half-maximal inhibitory concentration: > 50000 nM
Compound 4 gave a limit, no number (the forecaster's own chance of this, stated with the estimate: 30%); middle value at least 1.6-fold (0.22 log units) away from the limit.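

Compound 4 gives > 50000 nM, which is a limit and not a number, and since compound 3 also gives a limit, the step between them cannot be read. Against the compounds with readable values, hydrogen in place of butyl on the amide-type nitrogen gives an at least 1.9-fold higher number from compound 2 to compound 4 (0.29 log units; that floor lies within the scatter), while amino in place of propyl on the carbonyl carbon gives an at least 4.2-fold higher number from compound 1 to compound 4 (0.63 log units; beyond the scatter), so only the comparison with the propyl ketone clearly separates compound 4 from a measured number. The new information is that changing carboxy to carbamoyl on this carbonyl carbon does not yield a readable value, and the bare amide joins the acid at the same limit: the limit of > 50000 nM in this assay, at which 2 of the 4 values shown sit.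

The real potencies of compound 3 and compound 4 remain hidden behind their limits, so the two groups cannot be ranked against each other. From the compounds shown here alone, it also remains open whether a methylamino or propylamino group, or a methyl ester, on this same carbonyl carbon would give a readable value, and how far the length of the chain on the amide nitrogen matters.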